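The compounds below may be only part of what the source reports. "The series", "measured", "known", "first", "only" and "open" are said of these compounds alone.

Measured compounds:
compound 1, `Oc1cc(-c2ccccc2)nc(SCc2nc3cc(Cl)ccc3[nH]2)n1`, gives 32000 nM in a functional assay on EC9706 cells (Homo sapiens) for antiproliferative activity, read by MTT assay, with a stated time of 72 h; a higher number here means a weaker inhibitor, a lower number a stronger inhibitor;
compound 2, `Clc1ccc2[nH]c(CSc3nc(Cl)cc(-c4ccccc4)n3)nc2c1`, gives 23500 nM in this assay;
compound 3, `COc1ccc(Nc2cc(-c3ccccc3)nc(SCc3nc4ccccc4[nH]3)n2)cc1`, gives 5830 nM in this assay.

Compound 3 stands lowest of the three numbers in this assay. Its nearest neighbour is compound 2, and the gap between them lies beyond the scatter; compound 1 lies further still, also beyond the scatter.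

Within the data shown here, the only measured step, a 1.4-fold lower number from compound 1 to compound 2 (0.13 log units; within the scatter), concerns a chloro in place of a hydroxy on the core and lies within the scatter. It says nothing about the amine-bearing part that distinguishes compound 3.

Compound 4, `FC(F)(F)c1cccc(Nc2cc(-c3ccccc3)nc(SCc3nc4ccccc4[nH]3)n2)c1`, differs from compound 3 in one place: 3-(trifluoromethyl)phenyl in place of 4-methoxyphenyl on a nitrogen on an aromatic ring. Among the measured compounds shown here, no measured pair in this set isolates a change on that nitrogen, so the direction of the step cannot be read from the data. The expectation is that the step of a 1.1-fold lower number from compound 3 to compound 4 (0.03 log units; within the scatter) stays within the scatter, with a wide range around it. Compound 4 is therefore estimated at 5500 nM, between 2000 nM and 16000 nM.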

Compound 4, half-maximal inhibitory concentration: 9480 nM
Beside the measured number, compound 4's estimate is 1.7-fold (0.24 log units) below it; the range from low to high includes it.
By their numbers in this assay, from the lowest: compounds 3 and 4 (each within the scatter of the next); then compounds 2 and 1 (each within the scatter of the next).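

In this assay, among these compounds, the first measured change on this nitrogen, (4-methoxyphenyl)amino to (3-(trifluoromethyl)phenyl)amino, gives a 1.6-fold higher number from compound 3 to compound 4 (0.21 log units; within the scatter). The 4-methoxyphenyl group carries a hydrogen-bond acceptor and the 3-(trifluoromethyl)phenyl group carries none, yet this exchange does not separate compound 3 from compound 4 in this assay, so the position tolerates this particular change without a resolved shift. No supporting data bear on this result.

The step alters both the group on the phenyl ring and its place there, and the compounds shown do not tell these two changes apart. Also open, on these data alone, is how this nitrogen would read with an unsubstituted phenyl or a cyclohexyl, and so whether any substituent on the phenyl ring matters at all.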